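Moving the nitro group on the amide-side phenyl ring

This account rests on a few compounds, and the source may have more. Where it says the series, first, only, none or still open, it means among the compounds named here.

Compound 1, `O=C(CSc1nc(Nc2ccccc2)c2ccccc2n1)Nc1ccccc1Br`: 10300 nM in a functional assay on NCI-H1975 cells (Homo sapiens) for inhibition, read by MTT assay, with a stated time of 72 h; on this read-out lower numbers stand for stronger inhibition and higher numbers for weaker inhibition
Compound 2, `O=C(CSc1nc(Nc2ccccc2)c2ccccc2n1)Nc1cccc([N+](=O)[O-])c1`: 17900 nM in this assay
Compound 3, `CCc1cccc(NC(=O)CSc2nc(Nc3ccccc3)c3ccccc3n2)c1`: 12000 nM in this assay

The three measured compounds share one core and differ only in the aryl group on the amide-type nitrogen. Compound 2 carries the 3-nitrophenyl group; the step of a 1.7-fold higher number from compound 1 to compound 2 (0.24 log units; within the scatter) and the step of a 1.5-fold lower number from compound 2 to compound 3 (0.17 log units; within the scatter) both lie within the scatter, so compound 2 is not separated from either neighbour in this assay, and the step of a 1.2-fold higher number from compound 1 to compound 3 (0.07 log units; within the scatter) is likewise within the scatter. Across the set, none of the three aryl groups shifts the number beyond the scatter.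

Compound 4, `O=C(CSc1nc(Nc2ccccc2)c2ccccc2n1)Nc1ccc([N+](=O)[O-])cc1`, is the unmeasured partner of compound 2; the change is 4-nitrophenyl in place of 3-nitrophenyl on an amide-type nitrogen. Going by the values given here, no measured step moves a nitro group from one position to another, so the only guide is that every exchange on this nitrogen seen so far has stayed within the scatter. The change from compound 2 to compound 4 is therefore expected to give no step beyond the scatter, that is a 1.2-fold lower number from compound 2 to compound 4 (0.08 log units; within the scatter). Compound 4 is expected at 15000 nM, with a range from 6000 nM to 40000 nM.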

Compound 4, half-maximal inhibitory concentration: 13000 nM
Beside the measured number, compound 4's estimate is 1.2-fold (0.06 log units) above it; low and high end bracket the measured number.
By their numbers in this assay, from the lowest: compounds 1, 3, 4 and 2 (each within the scatter of the next).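

Moving the nitro group, with 4-nitrophenyl in place of 3-nitrophenyl on the amide-type nitrogen, gives the first direct reading of a change that keeps the same atoms and only joins them differently; in this assay the result is a 1.4-fold lower number from compound 2 to compound 4 (0.14 log units; within the scatter), so this exchange does not separate the two nitro compounds. The new group is not separated from the other aryl groups either, as shown by a 1.1-fold higher number from compound 3 to compound 4 (0.03 log units; within the scatter) and by a 1.3-fold higher number from compound 1 to compound 4 (0.10 log units; within the scatter), so every step among the four compounds now lies within the scatter. Nothing available on these compounds bears on why the numbers stay so close.

The compounds shown leave open whether any aryl group on this nitrogen can move the number beyond the scatter, since all four carry a substituted phenyl ring. From the compounds shown here alone, an amine or a carboxylic acid on that ring, or a longer alkyl chain in place of the ring, might give a clearer answer, and whether the close grouping would hold for such groups remains unknown.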